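Adding fluorine to a weakly cytotoxic bis-benzothiazole amine

This account rests on a few compounds, and the source may have more. Where it says the series, first, only, none or still open, it means among the compounds named here.

Compound 1, with the structure `Clc1cccc2sc(Nc3nc4ccccc4s3)nc12`, was tested in a functional assay on B16-F10 cells (Mus musculus) for cytotoxicity, read by MTT assay, with a stated time of 48 h; a lower number here means a stronger inhibitor, a higher number a weaker inhibitor. In this assay, among the compounds with values here, compound 1 gives 29500 nM, which is the only actual number in this small set; the other measured compound returns no number. That other compound is compound 2, with the structure `Fc1ccc2nc(Nc3nc4ccccc4s3)sc2c1`. For compound 2 this assay reports > 50000 nM; > 50000 nM (2 entries) twice, and each of these is a limit of the assay rather than a measured value, so compound 2 can only be said to lie beyond the range the assay covers.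

Compound 3, with the structure `Fc1ccc2nc(Nc3nc4c(Cl)cccc4s3)sc2c1`, has not yet been measured. It is built from compound 1 by the change (fluoro in place of hydrogen on an aromatic carbon).

Within the data shown here, no step between two measured compounds is available to gauge what such a change does in this assay. Given that compound 1 sits at 29500 nM, the step of a 1.4-fold higher number from compound 1 to compound 3 (0.13 log units; within the scatter) is expected to be small, toward a weaker inhibitor if anything, and may stay within the usual scatter. Compound 3 is therefore estimated at 40000 nM, with a range from 15000 nM to 100000 nM.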

Compound 3, half-maximal inhibitory concentration: > 50000 nM
Compound 3 ended at the assay's limit (the forecaster's own chance of this, stated with the estimate: 40%); at least 1.2-fold (0.09 log units) between middle value and limit.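

Within the data shown here, this is the first readable step for fluoro in place of hydrogen on an aromatic carbon of the core of compound 1, and in this assay it amounts to an at least 1.6-fold higher number from compound 1 to compound 3 (0.22 log units; that floor lies within the scatter) and that floor lies within the scatter, so the result shows no gain in strength but does not establish a real loss. Compound 3 gives > 50000 nM as a limit of the assay and not a number. Going by these compounds, the true size of the step stays unknown because the read-out for compound 3 stops at that limit: the limit of > 50000 nM in this assay, at which 1 of the 3 values shown sits.

Steps with a limit at both ends, such as the one between compound 2 and compound 3, cannot be read, so what the chloro group contributes alongside the fluoro stays open. Also open, on these data alone, is whether an amine or a methoxy group on this same aromatic carbon would bring the result inside the range of this assay and give a number that can be compared directly with compound 1.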